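A benzyl for sec-butyl swap in an oxime-linked series

This account rests on a few compounds, and the source may have more. Where it says the series, first, only, none or still open, it means among the compounds named here.

Of the compounds shown here, two have been measured in a physicochemical assay for lipophilicity, measured as octanol-water partition; a higher number here means a more lipophilic compound, a lower number a more polar compound. Compound 1, `CCO/N=C/Nc1cc(Cl)c(CC)c(Cl)c1`, gives 4.8 in this assay. Compound 2, `C#CCc1c(Cl)cc(N/C=N/OC(C)CC)cc1Cl`, gives 4.2 in this assay. Compound 2 thus stands as the lower of the two numbers, and the gap up to compound 1 lies beyond the usual scatter of such measurements.

Compound 3, `C#CCc1c(Cl)cc(N/C=N/OCc2ccccc2)cc1Cl`, has not yet been measured. It differs from compound 2 in one place: benzyl in place of sec-butyl on an oxygen. For the measured compounds named here, no measured pair shows this exact change, so the expectation rests only on the two numbers given and on the change itself.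

For compound 3 a modest upward step is expected, a number 0.30 log units higher from compound 2 to compound 3 (within the scatter) in this assay, though a result not beyond the scatter would be no surprise. The estimate for compound 3 in this assay is 4.5, with a likely range from 4 to 5.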

Compound 3, partition coefficient: 4.2
The estimate for compound 3 lay 0.30 log units above the measured number, and the stated range covers the measured number.
By their numbers in this assay, from the lowest: compounds 2 and 3 (each within the scatter of the next); then compound 1.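

On an oxygen, benzyl in place of sec-butyl gives no change at the digits printed from compound 2 to compound 3 (within the scatter) in this assay. For the compounds shown here, a group of 7 heavy atoms with one six-membered aromatic ring thus replaces a group of 4 heavy atoms with no ring, and the swap leaves no shift that can be told apart from the scatter of this assay, something the earlier compounds could not show because no measured pair tested a change at this position. Nothing on hand accounts for this outcome.

This single pair leaves open whether the same holds for other groups on this oxygen, such as a longer chain, or a benzyl carrying an amine or a carboxylic acid on its ring. It also leaves open whether the same swap would read alike on a different core.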